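Taking the acetyl group off compound 1

This account rests on a few compounds, and the source may have more. Where it says the series, first, only, none or still open, it means among the compounds named here.

Compound 1 `CC(=O)Nc1nc2ccnc(-c3cccc(NS(=O)(=O)c4ccc(C)cc4)c3)n2n1` gives 1600 nM
Compound 2 `CC(=O)Nc1nc2c(C)cnc(-c3cccc(NS(=O)(=O)c4ccc(C)cc4)c3)n2n1` gives 51800 nM

Going by the values given here, in a functional assay (Homo sapiens) (on this read-out higher numbers stand for weaker inhibition and lower numbers for stronger inhibition), compound 1 gives 1600 nM as the lower of the two numbers so far. Compound 3 `Cc1ccc(S(=O)(=O)Nc2cccc(-c3nccc4nc(N)nn34)c2)cc1` differs from it by hydrogen in place of acetyl on a nitrogen on an aromatic ring in one place, hydrogen in place of acetyl on a nitrogen on an aromatic ring. Among the compounds with values here, the only measured step, a 32-fold higher number from compound 1 to compound 2 (1.51 log units; beyond the scatter) for methyl in place of hydrogen on an aromatic carbon, is a different change. It shows that one edit can move this number far, but says nothing direct about the acetyl. A moderate rise is therefore expected, with wide uncertainty. An estimated 2.5-fold higher number from compound 1 to compound 3 (0.40 log units; beyond the scatter) is the expectation here. For compound 3 the estimated value is 4000 nM with a range from 800 nM to 25000 nM expected.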

Compound 3, half-maximal inhibitory concentration: 1500 nM
Beside the measured number, compound 3's estimate is 2.7-fold (0.43 log units) above it, and the stated range covers the measured number.
By their numbers in this assay, from the lowest: compounds 3 and 1 (each within the scatter of the next); then compound 2.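

In this assay, changing acetamido to amino gives a 1.1-fold lower number from compound 1 to compound 3 (0.03 log units; within the scatter) and so leaves the number within the usual scatter. At this nitrogen, then, the acetyl group can be removed without a measurable loss of inhibition, and the simple amino compound serves as well as the acetylated one. No available evidence bears on why the number holds.

Still open, on these data alone, is how this nitrogen responds to a larger group, such as a longer acyl chain, a urea or a sulfonamide. Also open, as far as these compounds go, is whether adding the ring methyl of compound 2 to the amino compound would raise the number as it does with the acetyl group present.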